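Nitroimidazooxazine series: cytotoxicity on human fibroblasts

The source may hold more compounds than are shown below. What is called first, only, known or untested is meant among the compounds shown, and "the series" means these compounds.

Measured compounds:
compound 1 `O=[N+]([O-])c1cn2c(n1)OC(COc1ccc(-c3ccc(OC(F)(F)F)cc3)cn1)CC2` — > 64000 nM
compound 2 `O=[N+]([O-])c1cn2c(n1)OC(COc1ccc(-c3ccc(F)cc3)nn1)CC2` — > 64000 nM
compound 3 `O=[N+]([O-])c1cn2c(n1)OC(COc1ccc(-c3ccc(F)nc3F)cn1)CC2` — > 64000 nM

All three values come from an ADME assay on MRC5 cells (Homo sapiens) for cytotoxicity, read by resazurin assay, with a stated time of 72 h; a higher number here means a weaker inhibitor, a lower number a stronger inhibitor. Each is a limit of the assay, not a number. In this assay compound 1 gives > 64000 nM, a limit. Compound 2 likewise gives only a limit, > 64000 nM. Compound 3 gives only a limit too, > 64000 nM. Going by the values given here, compound 1 therefore cannot be placed against the others: the limit of > 64000 nM in this assay, at which 3 of the 3 values shown sit, shows that every value in the set sits at the same limit, so no order can be read among compounds 1, 2 and 3, and no step between measured compounds is available.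

The next compound, compound 4 `CC1(COc2ccc(-c3ccc(OC(F)(F)F)cc3)cn2)CCn2cc([N+](=O)[O-])nc2O1`, differs from compound 1 in one place: methyl in place of hydrogen on a saturated ring carbon. Nothing in the measured set allows a direction for this change to be read, and with compound 1 at the limit any small step would stay hidden. The step is expected to be none beyond the scatter, a step that the limit leaves unreadable from compound 1 to compound 4. For compound 4 the value in this assay is estimated at 100000 nM, within 64000 nM to 250000 nM, most likely reported again as a limit.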

Compound 4, half-maximal inhibitory concentration: > 64000 nM
Compound 4: a limit, no number; the forecaster's own chance of this, stated with the estimate: 85%; the middle value does not contradict the limit.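

In this assay compound 4 gives > 64000 nM, a limit and not a number. No step can be read between compound 1 and compound 4: the limit of > 64000 nM in this assay, at which 4 of the 4 values shown sit.

On these data alone, whether methyl in place of hydrogen alters cytotoxicity, and how the four compounds rank, stays open.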